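Moving a methyl around the ring on the carbonyl carbon

A few compounds are considered here, and "the series" means these few. Any claim that something is new, unique, unknown or untested is made for them only; others in the source may bear on it.

Three compounds share a common core and differ only in the aryl group attached to the carbonyl carbon. Compound 1 `COc1ccc(/C=C/c2cc(OC)cc(OC)c2/C=C/C(=O)c2ccc(C)cc2)cc1` carries a 4-methylphenyl there and gives 3.6 ug/mL in a functional assay on A549 cells (Homo sapiens) for antiproliferative activity, read by MTT assay, with a stated time of 48 h; a higher number here means a weaker inhibitor, a lower number a stronger inhibitor. Compound 2 `CCCCOc1ccc(C(=O)/C=C/c2c(/C=C/c3ccc(OC)cc3)cc(OC)cc2OC)cc1` gives 8.7 ug/mL, and compound 3 `COc1ccc(/C=C/c2cc(OC)cc(OC)c2/C=C/C(=O)c2cccc(Cl)c2)cc1` gives 5.6 ug/mL. Going by the values given here, compound 1 therefore has the lowest number of the three, but only the step of a 2.4-fold higher number from compound 1 to compound 2 (0.38 log units; beyond the scatter) lies beyond the scatter, while the step of a 1.6-fold higher number from compound 1 to compound 3 (0.19 log units; within the scatter) does not, so compound 1 and compound 3 cannot be told apart.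

Compound 4 `COc1ccc(/C=C/c2cc(OC)cc(OC)c2/C=C/C(=O)c2ccccc2C)cc1` has not yet been measured. Relative to compound 1, the change is 2-methylphenyl in place of 4-methylphenyl on a carbonyl carbon. The two measured steps that touch this same ring, a 2.4-fold higher number from compound 1 to compound 2 (0.38 log units; beyond the scatter) and a 1.6-fold lower number from compound 2 to compound 3 (0.19 log units; within the scatter), were modest or within scatter, so the ring on the carbonyl carbon seems to tolerate changes without large shifts. A small step, if any, is expected: a 1.3-fold higher number from compound 1 to compound 4 (0.10 log units; within the scatter). Compound 4 is therefore estimated at 4.5 ug/mL, with a range from 2.5 ug/mL to 9 ug/mL.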

Compound 4, half-maximal inhibitory concentration: 5.9 ug/mL
For compound 4 the middle estimate is 1.3-fold (0.12 log units) below the measured one; measured number inside the range.
By their numbers in this assay, from the lowest: compounds 1, 3, 4 and 2 (each within the scatter of the next, the first and the last beyond it).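

Shifting the methyl from 4-methylphenyl to 2-methylphenyl on the carbonyl carbon, with the same atoms joined differently, gives a 1.6-fold higher number from compound 1 to compound 4 (0.21 log units; within the scatter) in this assay, so this assay cannot tell the two placements apart. Compound 4 also stays within the scatter of the other two, with a 1.1-fold higher number from compound 3 to compound 4 (0.02 log units; within the scatter) and a 1.5-fold lower number from compound 2 to compound 4 (0.17 log units; within the scatter), so it lies close to both even though compound 1 and compound 2 are separated by more than the scatter. No measurement at hand offers an explanation for these results.

Still open, as far as these compounds go, is whether an amine or a carboxylic acid on this ring, or a chain longer than butoxy, would move the number further than any step seen so far. From the compounds shown here alone, whether the ring on the carbonyl carbon can be replaced by something other than a substituted phenyl also remains open.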